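The source may hold more compounds than are shown below. What is called first, only, known or untested is meant among the compounds shown, and "the series" means these compounds.

Among the measured compounds shown here, compound 1 `Cc1c(-n2c(-c3ccccc3)c(-c3ccccc3)c3c(Nc4ccccc4)ncnc32)n(C)n(-c2ccccc2)c1=O` carries the higher of the two numbers measured so far, but only by a gap that lies within the usual scatter, so it cannot be set apart from its companion. In a functional assay on the whole organism (strain Sprague-Dawley) for inhibition, with Rattus norvegicus as the target, read by paw edema, with stated times of 1 h and 4 h, at a dose of 70 mg/kg by the subcutaneous route (a lower number here means less inhibition, a higher number more inhibition at the dose given (going by the name of the read-out)), compound 1 gives 27.9%. Compound 2 `Cc1nc2c(c(-c3ccccc3)c(-c3ccccc3)n2-c2c(C)c(=O)n(-c3ccccc3)n2C)c(=O)[nH]1`, built on the same core, gives 27.7% in this assay, a value that sits within the scatter of compound 1. For the measured compounds named here, no pair of measured compounds differing in one place is available, so no measured step can guide the next comparison. Compound 3 `Cc1c(-n2c(-c3ccccc3)c(-c3ccccc3)c3c(NN)ncnc32)n(C)n(-c2ccccc2)c1=O` differs from compound 1 in one place: amino in place of phenyl on a nitrogen on an aromatic ring. Nothing measured here bears on this change, and the expected step is a number 2.9 percentage points lower from compound 1 to compound 3 (within the scatter), nothing beyond the scatter in either direction. Compound 3 is therefore estimated to give about 25% in this assay, within a range from 8% to 42%.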

Compound 3, a percentage reported as inhibition, in the whole organism at one dose (the size of the read-out at that dose, not a potency): 54%
Estimate against measurement, compound 3: 29 percentage points below; measured number above the stated range.
By their numbers in this assay, from the lowest: compounds 2 and 1 (each within the scatter of the next); then compound 3.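

In this assay, phenyl gives way to amino on a nitrogen on an aromatic ring, and this single change amounts to a number 26.1 percentage points higher from compound 1 to compound 3 (beyond the scatter). Among the compounds shown here, this is the first sign that this position can move the read-out, which the two earlier compounds, differing from each other in more than one place, could not show. The exchange removes a six-membered aromatic ring of carbon only and adds a nitrogen that counts as a hydrogen-bond donor and acceptor, but no measurement here bears on why the number rises.

The compounds shown leave open whether the rise follows from losing the phenyl or from gaining the amino, which a methyl or a hydroxyl in the same place could separate. From the compounds shown here alone, it is also open whether a longer chain, such as aminoethyl, would keep the higher number.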